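Cytotoxicity notes: three measured analogues, one pending

A few compounds are considered here, and "the series" means these few. Any claim that something is new, unique, unknown or untested is made for them only; others in the source may bear on it.

Measured so far in an ADME assay on HepG2 cells (Homo sapiens) for cytotoxicity, read by luminescence, CellTiter-Glo and ATP content, with a stated time of 72 h; on this read-out lower numbers stand for an effect already at smaller amounts and higher numbers for an effect only at larger amounts of compound:
compound 1 `COc1ccc(Oc2ccc3c(NCCCNCc4cc(F)ccc4OC)ccnc3c2)cc1` gives 7000 nM
compound 2 `COc1ccc(F)cc1CNCCCNc1ccnc2cc(Cc3ccc(F)cc3)ccc12` gives 3530 nM
compound 3 `COc1ccc(F)cc1CNCCCNc1ccnc2cc(Cc3ccc(C#N)cc3)ccc12` gives 6050 nM

Compound 3 sits second highest of the three; the nearest step is a 1.2-fold lower number from compound 1 to compound 3 (0.06 log units; within the scatter) and the furthest is a 1.7-fold higher number from compound 2 to compound 3 (0.23 log units; within the scatter), so all three numbers lie inside the usual scatter of one another. Compound 4 `COc1ccc(-c2ccc3c(NCCCNCc4cc(F)ccc4OC)ccnc3c2)cc1` is not yet measured; it differs from compound 3 by 4-methoxyphenyl in place of 4-cyanobenzyl on an aromatic carbon.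

Among the measured compounds shown here, the steps that bear on this are those that replace the same substituent: a 2.0-fold lower number from compound 1 to compound 2 (0.30 log units; within the scatter) and a 1.2-fold lower number from compound 1 to compound 3 (0.06 log units; within the scatter), both inside the scatter. Compound 1 carries a group most akin to what enters in compound 4, and its number is close to that of compound 3. For the measured compounds named here, with no step reaching beyond the scatter, no step beyond the scatter is expected for compound 4 in this assay either, so the estimated step is a 1.0-fold higher number from compound 3 to compound 4 (0.02 log units; within the scatter).

Compound 4 is thus estimated at 6300 nM, with a range of 3000 nM to 13000 nM.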

Compound 4, half-maximal effective concentration: 5960 nM
Compound 4: middle estimate off by 1.1-fold (0.02 log units), on the high side; the measured number falls inside the stated range.
By their numbers in this assay, from the lowest: compounds 2, 4, 3 and 1 (each within the scatter of the next).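

At this position, on an aromatic carbon of the shared core, 4-methoxyphenyl now stands with 4-cyanobenzyl (a 1.0-fold lower number from compound 3 to compound 4 (0.01 log units; within the scatter)), 4-fluorobenzyl (a 1.7-fold higher number from compound 2 to compound 4 (0.23 log units; within the scatter)) and 4-methoxyphenoxy (a 1.2-fold lower number from compound 1 to compound 4 (0.07 log units; within the scatter)), and all three steps in this assay lie within the scatter. The earlier compounds shown here did not include an aromatic ring joined to the core in this way, so the series now shows that this change of attachment does not separate compound 4 from the others on this read-out. The data on hand offer no explanation for how closely these numbers agree.

Still open, on these data alone, is whether a group without an aromatic ring, such as a morpholine or a carboxylic acid, would give a step beyond the scatter at this position. Also open, as far as these compounds go, is whether an amine or a longer chain on the 4-methoxyphenyl ring would do so.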